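Benzyl ring substituents in a fused lactam series

A few compounds are considered here, and "the series" means these few. Any claim that something is new, unique, unknown or untested is made for them only; others in the source may bear on it.

Three compounds share one core and differ only in the substituent pattern of the benzyl group on the lactam nitrogen. In a functional assay on HepG2 cells (Homo sapiens) for inhibition, read by MTT assay, with a stated time of 72 h (on this read-out lower numbers stand for stronger inhibition and higher numbers for weaker inhibition), compound 1 `Cc1ccc(CN2CCc3ncn(COCc4ccccc4)c3/C(=C/c3ccccc3)C2=O)cc1` gives 44700 nM. Compound 2 `O=C1/C(=C\c2ccccc2)c2c(ncn2COCc2ccccc2)CCN1Cc1ccc(F)cc1` gives 39400 nM in this assay, and compound 3 `Cc1cc(C)cc(CN2CCc3ncn(COCc4ccccc4)c3/C(=C/c3ccccc3)C2=O)c1` gives 40900 nM. Compound 3 thus holds the second highest of the three numbers, nearest to compound 2 and furthest from compound 1, with both gaps inside the scatter; the three cannot be ordered.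

Compound 4 `Cc1cccc(CN2CCc3ncn(COCc4ccccc4)c3/C(=C/c3ccccc3)C2=O)c1` is the next step from compound 3: hydrogen in place of methyl on an aromatic carbon, that is, 3,5-dimethylphenyl becomes 3-methylphenyl. Within the data shown here, two measured steps concern the same benzyl ring. Step a 1.1-fold lower number from compound 1 to compound 3 (0.04 log units; within the scatter) and step a 1.0-fold higher number from compound 2 to compound 3 (0.02 log units; within the scatter) both moved the number by no more than the scatter, and a 1.1-fold lower number from compound 1 to compound 2 (0.05 log units; within the scatter) also stayed within it. Every exchange on this ring so far has left this assay essentially unchanged, so no step beyond the scatter is expected from a 1.0-fold higher number from compound 3 to compound 4 (0.00 log units; within the scatter) in either direction.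

Compound 4 is therefore expected to give about 41000 nM in this assay, within a range of 20000 nM to 82000 nM.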

Compound 4, half-maximal inhibitory concentration: 34300 nM
Compound 4: middle estimate off by 1.2-fold (0.08 log units), on the high side; the measured number falls inside the stated range.
By their numbers in this assay, from the lowest: compounds 4, 2, 3 and 1 (each within the scatter of the next).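

Working notes: in this assay, hydrogen in place of methyl on this aromatic carbon, meta to a large group and meta to a methyl group, is the first exchange in the set that simply removes a ring substituent, and it stays within the scatter (a 1.2-fold lower number from compound 3 to compound 4 (0.08 log units; within the scatter)). The 3-methylphenyl group of compound 4 also cannot be told apart from 4-fluorophenyl (a 1.1-fold lower number from compound 2 to compound 4 (0.06 log units; within the scatter)) or from 4-methylphenyl (a 1.3-fold lower number from compound 1 to compound 4 (0.12 log units; within the scatter)), so one methyl group at either printed ring place, two methyl groups and one fluoro group all read alike here, with no exception among the four compounds. Nothing available bears on why these benzyl groups read alike.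

Going by these compounds, whether an unsubstituted benzyl group, a carboxylic acid or dimethylamino group on this ring, or a longer chain such as phenethyl on the lactam nitrogen would move the number beyond the scatter stays open. Also open, on these data alone, is whether any exchange outside this benzyl ring would do so, since all four compounds share the rest of the structure.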